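Amino group added to compound 2

The source may report more compounds than this note shows. Statements on the series, on what has been measured and on what is new or still open speak of the compounds shown alone.

In a functional assay on PC-3 cells (Homo sapiens) for cytotoxicity, read by MTT assay, with a stated time of 48 h (on this read-out lower numbers stand for stronger inhibition and higher numbers for weaker inhibition), compound 1 (`COc1ccc(-c2c[nH]c(=O)n2-c2cc(OC)c(OC)c(OC)c2)cc1N`) gives 49800 nM and compound 2 (`COc1ccc(-c2cn(C(=O)Nc3cc(OC)c(OC)c(OC)c3)c(=O)n2-c2cc(OC)c(OC)c(OC)c2)cc1`) gives 49700 nM so the two stand level, within the scatter of each other. Compound 3 (`COc1ccc(-c2cn(C(=O)Nc3cc(OC)c(OC)c(OC)c3)c(=O)n2-c2cc(OC)c(OC)c(OC)c2)cc1N`) has amino in place of hydrogen on an aromatic carbon, ortho to a methoxy group (amino in place of hydrogen on an aromatic carbon). The 3-amino-4-methoxyphenyl group is already present in compound 1 at 49800 nM so no large gain is expected from it. The expected step of a 1.7-fold lower number from compound 2 to compound 3 (0.22 log units; within the scatter) in this assay stays within the scatter, leaning slightly toward stronger inhibition. For compound 3 the estimated value is 30000 nM with an expected range of 6000 nM to 90000 nM in this series.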

Compound 3, half-maximal inhibitory concentration: 10000 nM
Compound 3: the middle estimate sits 3.0-fold (0.48 log units) above what was measured; low and high end bracket the measured number.
By their numbers in this assay, from the lowest: compound 3; then compounds 2 and 1 (each within the scatter of the next).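

In this assay the amino group, ortho to a methoxy group, gives a 5.0-fold lower number from compound 2 to compound 3 (0.70 log units; beyond the scatter) and so shows that this position on the 4-methoxyphenyl group can respond to a single added atom. Compound 1 carries the same 3-amino-4-methoxyphenyl group and gives 49800 nM while compound 3 gives 10000 nM and so that group alone does not set the value of compound 3. Whether a hydroxyl group or a dimethylamino group at this position would give a similar step stays open, as does the reason for this step, on which no supporting data are available.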